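The compounds below may be only part of what the source reports. "The series", "measured", "known", "first", "only" and "open" are said of these compounds alone.

Among the compounds with values here, compound 3 `CN(C)CCCn1c(=O)n(C2OC(CO)[C@@H](O)[C@H]2O)c2nc(N)nc(O)c21` gives 83% in a functional assay on the whole organism (B cells) with Mus musculus as the target (a higher number here means a larger maximal response, a lower number a smaller maximal response), which is the lowest of the three numbers so far. Compound 1 `NCC(O)Cn1c(=O)n(C2OC(CO)[C@@H](O)[C@H]2O)c2nc(N)nc(O)c21` gives 110% and compound 2 `Nc1nc(O)c2c(n1)n(C1OC(CO)[C@@H](O)[C@H]1O)c(=O)n2Cc1ccccc1` gives 110%; the step of a number 27 percentage points lower from compound 1 to compound 3 (beyond the scatter) and the step of a number 27 percentage points lower from compound 2 to compound 3 (beyond the scatter) both describe the same place on the saturated chain carbon bound to an aromatic nitrogen, and each is modest but beyond the scatter.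

Compound 4 `Nc1nc(O)c2c(n1)n(C1OC(CO)[C@@H](O)[C@H]1O)c(=O)n2CC(O)CO` has not yet been measured. Its difference from compound 3 is 1,2-dihydroxyethyl in place of 2-(dimethylamino)ethyl on a saturated chain carbon bound to an aromatic nitrogen. Both earlier steps that bear on this place show that the 2-(dimethylamino)ethyl group of compound 3 goes with a lower maximal response, while the 2-amino-1-hydroxyethyl of compound 1, which like the incoming group carries hydroxyl, gives 110%. An expected step of a number 22 percentage points higher from compound 3 to compound 4 (beyond the scatter) upward therefore seems reasonable. Compound 4 is estimated to give 105%, expected between 85% and 125%.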

Compound 4, largest response reached (reported as maximal response), in percent of the reference or control that the assay uses: 136%
Estimate against measurement, compound 4: 31 percentage points below; the measured number lies above the stated range.
By their numbers in this assay, from the lowest: compound 3; then compounds 1 and 2 (each within the scatter of the next); then compound 4.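

In this assay, within the data shown here, the place on a saturated chain carbon bound to an aromatic nitrogen proves able to carry the response well beyond the level shared by compounds 1 and 2: 1,2-dihydroxyethyl gives the largest step so far (a number 53 percentage points higher from compound 3 to compound 4 (beyond the scatter)) and also exceeds phenyl (a number 26 percentage points higher from compound 2 to compound 4 (beyond the scatter)). The result further shows that a single change on the chain matters, with hydroxy in place of amino giving a clear rise (a number 26 percentage points higher from compound 1 to compound 4 (beyond the scatter)), whereas the very different groups of compounds 1 and 2 had shown no separation. No measurement shown here gives a reason for these steps.

The compounds shown leave open whether a chain with one hydroxy group, a methyl ether of the diol or a carboxylic acid would keep this higher response. They also leave open whether a longer chain bearing both hydroxy groups would do so.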